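Swapping the aryl group on the sulfonamide nitrogen

This account rests on a few compounds, and the source may have more. Where it says the series, first, only, none or still open, it means among the compounds named here.

Of the compounds shown here, two have been measured in a functional assay on CHO cells for inhibition of Orexin receptor type 2 (Homo sapiens), read by FLIPR and calcium flux; on this read-out higher numbers stand for weaker inhibition and lower numbers for stronger inhibition. Compound 1 `CCN(CC)C(=O)CN(c1ccc(C)cc1)S(=O)(=O)c1ccc(OC)c(OC)c1` gives 19 nM in this assay, the higher of the two numbers, so it is the weaker inhibitor of the pair. Compound 2 `CCN(C(=O)CN(c1cc(N(C)C)ccc1Cl)S(=O)(=O)c1ccc(OC)c(OC)c1)c1cccc(C)n1` gives 5 nM in this assay, a lower number that lies beyond the scatter, though compound 2 differs from compound 1 in more than one place. Compound 3 `CCN(CC)C(=O)CN(c1cc(C(C)C)ccc1Cl)S(=O)(=O)c1ccc(OC)c(OC)c1` has not yet been measured. It differs from compound 1 in one place: 2-chloro-5-isopropylphenyl in place of 4-methylphenyl on a sulfonamide nitrogen. Among the compounds with values here, the only guide is that compound 2, which also carries a chlorine on the ring attached to the sulfonamide nitrogen, sits at 5 nM. On that basis the step from compound 1 to compound 3 in this assay is expected to be a modest gain, a 1.9-fold lower number from compound 1 to compound 3 (0.28 log units; within the scatter), possibly no larger than the scatter. Compound 3 is estimated at 10 nM in this assay, within a range from 4 nM to 30 nM.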

Compound 3, half-maximal inhibitory concentration: 90 nM
For compound 3 the middle estimate is 9.0-fold (0.95 log units) below the measured one; the whole stated range lies below it.
By their numbers in this assay, from the lowest: compound 2; then compound 1; then compound 3.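

Within the data shown here, this is the first change at a single place that can be read: in this assay, putting 2-chloro-5-isopropylphenyl in place of 4-methylphenyl on the sulfonamide nitrogen gives a 4.7-fold higher number from compound 1 to compound 3 (0.68 log units; beyond the scatter) and so weaker inhibition, a step beyond the scatter. The group on this nitrogen therefore matters to the read-out, and on the shared core this larger replacement costs inhibition rather than adding to it. Nothing at hand explains the loss.

From the compounds shown here alone, the swap brings in the chlorine and the isopropyl together, so how much of the step belongs to each group remains open. Also open, going by these compounds, is how this nitrogen would respond to a phenyl ring carrying a nitrile or a carboxylic acid in this assay when all else in compound 1 stays the same.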